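Shifting the Thiophene Attachment on Compound 2

The compounds below may be only part of what the source reports. "The series", "measured", "known", "first", "only" and "open" are said of these compounds alone.

Compound 1 `CCOC(=O)C1=C(C)N(C)C(=O)NC1c1cccs1` and compound 2 `CC1=C(C(=O)OC(C)(C)C)C(c2cccs2)NC(=O)N1C` share one core and differ only in the ester. In an assay on membranes from HeLa cells for displacement of a labelled ligand from adenosine receptor A3 (Homo sapiens), read by scintillation counting, with a stated time of 180 min, tested at 1 uM (on this read-out lower numbers stand for less inhibition and higher numbers for more inhibition at the one concentration tested (going by the name of the read-out)), compound 1 gives 2%, while compound 2 gives 22%. The step of a number 20 percentage points higher from compound 1 to compound 2 (beyond the scatter) is beyond the scatter and leaves the tert-butyl ester as the higher of the two numbers shown, so compound 2 stands highest of the two. Compound 3 `CC1=C(C(=O)OC(C)(C)C)C(c2ccsc2)NC(=O)N1C` keeps that tert-butyl ester and changes only the thiophene: thiophen-3-yl in place of thiophen-2-yl on a saturated ring carbon. Within the data shown here, no measured step bears on this change; the one step available, a number 20 percentage points higher from compound 1 to compound 2 (beyond the scatter), concerns the ester alone and says nothing about how the thiophene is joined. With nothing to support a move in either direction, the expected step is within the scatter: a number 2 percentage points lower from compound 2 to compound 3 (within the scatter). Compound 3 is therefore estimated at 20% in this assay, with a range from 5% to 40%.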

Compound 3, a percentage reported as inhibition, at one concentration (the size of the read-out at that concentration, not a potency): 14%
Compound 3: the middle estimate sits 6 percentage points above what was measured; the range from low to high includes it.
By their numbers in this assay, from the lowest: compound 1; then compounds 3 and 2 (each within the scatter of the next).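

In this assay, the change from thiophen-2-yl to thiophen-3-yl on the saturated ring carbon gives a number 8 percentage points lower from compound 2 to compound 3 (within the scatter) and so cannot be told apart from no change. Compound 1 and compound 2 showed only that the ester matters; this pair shows that, with the tert-butyl ester in place, how the thiophene is joined at this carbon makes no clear difference at the one concentration tested. Nothing measured here offers an explanation for this result.

Still open, on these data alone, is whether thiophen-3-yl would behave the same alongside the ethyl ester of compound 1. Also open, as far as these compounds go, is whether a phenyl ring at this carbon, or an amine or a carboxylic acid on the thiophene, would move the number beyond the scatter.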